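The compounds below may be only part of what the source reports. "The series", "measured", "known", "first", "only" and "open" are said of these compounds alone.

Measured so far:
Compound 1, `COc1ccc(S(=O)(=O)NC(=O)Nc2ccc(Cl)cc2)s1` — 93%
Compound 2, `CCCc1ccc(S(=O)(=O)NC(=O)Nc2ccc(Cl)cc2)s1` — 38%
Compound 3, `CC(C)(C)c1ccc(S(=O)(=O)NC(=O)Nc2ccc(Cl)cc2)s1` — 7%

In a functional assay on the whole organism (6C3HED cells, Mus musculus) for inhibition, at a dose of 150 mg/kg by the oral route (on this read-out higher numbers stand for more inhibition at the one dose given (going by the name of the read-out) and lower numbers for less inhibition), compound 1 stands highest of the three; its nearest neighbour is compound 2, with a number 55 percentage points lower from compound 1 to compound 2 (beyond the scatter), and the furthest is compound 3, with a number 86 percentage points lower from compound 1 to compound 3 (beyond the scatter). Compound 4, `CCc1csc(S(=O)(=O)NC(=O)Nc2ccc(Cl)cc2)c1`, has not been measured. It differs from compound 1 at the sulfonyl sulfur: a group of 7 heavy atoms (6 carbon, 1 sulfur; one five-membered aromatic ring with 1 hetero atom) in place of a group of 7 heavy atoms (5 carbon, 1 oxygen, 1 sulfur; one five-membered aromatic ring with 1 hetero atom), on a sulfonyl sulfur. The entering group carries an ethyl chain and no methoxy, so the leaving 5-methoxythiophen-2-yl takes the methoxy group with it. The two measured steps from compound 1 bear directly on this: the step to compound 2 put propyl in place of methoxy, the step to compound 3 put tert-butyl in place of methoxy, and both fell far beyond the scatter, the smaller alkyl group losing less (a number 31 percentage points lower from compound 2 to compound 3 (beyond the scatter)). Since compound 4 also trades the methoxy for an alkyl group, a large downward step in this assay is expected, a number 58 percentage points lower from compound 1 to compound 4 (beyond the scatter). Compound 4 is estimated at 35%, within 10% to 65%.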

Compound 4, a percentage reported as inhibition, in the whole organism at one dose (the size of the read-out at that dose, not a potency): 55%
Estimate against measurement, compound 4: 20 percentage points below, and the stated range covers the measured number.
By their numbers in this assay, from the lowest: compound 3; then compound 2; then compound 4; then compound 1.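

In this assay, a number 38 percentage points lower from compound 1 to compound 4 (beyond the scatter) shows that a large loss occurs even when the entering group adds no heavy atoms, since both groups on the sulfonyl sulfur hold 7, whereas propyl and tert-butyl were each larger than the methoxy they replaced. Compound 4 still gives 55%, so a group without methoxy can retain a substantial part of the read-out at this dose. No measurement shown here accounts for the loss.

Because the whole group on the sulfonyl sulfur changes in this step, the compounds shown do not separate the loss of the methoxy from the gain of the ethyl chain. On these data alone, it also remains open how an ethoxy group, a hydroxyl group or a dimethylamino group would fare in place of the methoxy on the 5-methoxythiophen-2-yl group.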